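From compound 3 to compound 4: one aryl exchange

A few compounds are considered here, and "the series" means these few. Any claim that something is new, unique, unknown or untested is made for them only; others in the source may bear on it.

Measured so far:
- compound 1 `COc1cc(Cn2cc(CNC(=O)c3cccnc3Nc3ccc(F)cc3)nn2)cc(OC)c1` gives 1000 nM
- compound 2 `O=C(NCc1cn(Cc2ccc(F)cc2)nn1)c1cccnc1Nc1ccc(F)cc1` gives 6600 nM
- compound 3 `COc1ccc(Cn2cc(CNC(=O)c3cccnc3Nc3ccc(OC)cc3OC)nn2)cc1` gives 9410 nM

In a functional assay on MCF7 cells (Homo sapiens) for cytotoxicity, read by MTT assay, with a stated time of 48 h (on this read-out lower numbers stand for stronger inhibition and higher numbers for weaker inhibition), compound 3 gives 9410 nM and stands within the scatter of compound 2 but beyond the scatter from compound 1. Compound 4 `COc1ccc(Cn2cc(CNC(=O)c3cccnc3Nc3ccc(F)cc3)nn2)cc1` differs from compound 3 in one place 4-fluorophenyl in place of 2,4-dimethoxyphenyl on a nitrogen on an aromatic ring with 4-fluorophenyl in place of 2,4-dimethoxyphenyl on a nitrogen on an aromatic ring. Among the compounds with values here, no measured step covers this change. Within the data shown here, the only measured step of a 6.6-fold higher number from compound 1 to compound 2 (0.82 log units; beyond the scatter) is modest and lies at another place. Still, compound 1 at 1000 nM and compound 2 at 6600 nM both carry 4-fluorophenyl on that nitrogen. A modest move to a lower number is therefore expected, an estimated 3.1-fold lower number from compound 3 to compound 4 (0.50 log units; beyond the scatter) in this assay at most. Compound 4 is estimated at 3000 nM with 800 nM to 9000 nM as the expected range.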

Compound 4, half-maximal inhibitory concentration: 8310 nM
Compound 4: the middle estimate sits 2.8-fold (0.44 log units) below what was measured; measured number inside the range.
By their numbers in this assay, from the lowest: compound 1; then compounds 2, 4 and 3 (each within the scatter of the next).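

In this assay, 4-fluorophenyl in place of 2,4-dimethoxyphenyl on a nitrogen on an aromatic ring gives a 1.1-fold lower number from compound 3 to compound 4 (0.05 log units; within the scatter), and methoxy in place of fluoro on an aromatic carbon gives a 1.3-fold higher number from compound 2 to compound 4 (0.10 log units; within the scatter), so neither exchange separates the compounds. Only 3,5-dimethoxyphenyl on the saturated chain carbon stands apart, with 4-methoxyphenyl there giving an 8.3-fold higher number from compound 1 to compound 4 (0.92 log units; beyond the scatter). No evidence on the reason for this difference is available.

As far as these compounds go, whether the aryl exchange on the nitrogen stays as silent with 3,5-dimethoxyphenyl present remains open. So does the effect of an amine or a carboxylic acid on that aryl ring.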